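Removing One Fluorine From Compound 2

The source may hold more compounds than are shown below. What is called first, only, known or untested is meant among the compounds shown, and "the series" means these compounds.

Compound 1 `O=[N+]([O-])c1ccc(C2=NOC(c3ccc(N4CCCCC4)cc3)C2)o1` gives 98.8%
Compound 2 `O=C1COCCN1c1ccc(C2CC(c3ccc([N+](=O)[O-])o3)=NO2)cc1F` gives 79.7%

In an ADME assay on a cell-free system (plasma, Mus musculus) for protein binding, read by LC-MS, with a stated time of 4 h, tested at 10 uM, compound 2 stands at 79.7% and has the larger unbound fraction of the two, a gap to compound 1 that lies beyond the scatter. Compound 3 `O=C1COCCN1c1ccc(C2CC(c3ccc([N+](=O)[O-])o3)=NO2)cc1` is compound 2 with hydrogen in place of fluoro on an aromatic carbon and is otherwise the same. Among the compounds with values here, no measured pair shows what this swap does, and the two measured compounds differ in more than one place, so the expectation rests on little. A small shift toward more free compound seems likeliest. The estimate is a 1.2-fold higher unbound fraction from compound 2 to compound 3 (0.07 log units; within the scatter) and this expected step stays within the scatter. Compound 3 is expected at 76% in this assay with an estimated range from 60% to 88% for the measurement.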

Compound 3, plasma protein binding: 66%
For compound 3 the middle estimate is 1.4-fold (0.15 log units) (unbound fraction) below the measured one; the range from low to high includes it.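

In this assay, the fluoro on the aromatic carbon ortho to the 3-oxomorpholin-4-yl group turns out to matter little: the swap to hydrogen gives a 1.7-fold higher unbound fraction from compound 2 to compound 3 (0.22 log units; within the scatter), so the two compounds cannot be told apart at this position. Within the data shown here, compound 3 also gives the first comparison that differs in one place only, and replacing piperidin-1-yl with 3-oxomorpholin-4-yl gives a 28-fold higher unbound fraction from compound 1 to compound 3 (1.45 log units; beyond the scatter), a large step that ties the wide gap in free compound to that group rather than to the fluoro. Nothing available explains either step.

Going by these compounds, it remains open whether a larger group on the same carbon, such as chloro or methyl, would also stay within the scatter. How an open-chain amine would compare with these two ring groups is equally unresolved.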